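Swapping a ring hydrogen for chlorine on a shared scaffold

A few compounds are considered here, and "the series" means these few. Any claim that something is new, unique, unknown or untested is made for them only; others in the source may bear on it.

Measured compounds:
Compound 1 `CCCc1nc(-c2ccccc2)c(CNCCN2CCN(c3ccc(OC)cc3)CC2)o1` gives 9200 nM in an assay on HEK293 cells for inhibition of Voltage-dependent T-type calcium channel subunit alpha-1G (Homo sapiens), read by patch clamp; on this read-out higher numbers stand for weaker inhibition and lower numbers for stronger inhibition.
Compound 2 `CCCc1nc(-c2ccccc2)c(CNCCN2CCN(c3ccccc3)CC2)o1` gives 10300 nM in this assay.

Compound 2 and compound 1 share a common core and differ only at one spot on the outer six-membered ring of carbon only. Their two numbers lie within the usual scatter of each other, so neither can be called the stronger inhibitor; compound 2 simply carries the higher of the two numbers by a small margin.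

The step that produced compound 2 from compound 1, a 1.1-fold higher number from compound 1 to compound 2 (0.05 log units; within the scatter), removed a methoxy group and left a hydrogen in its place. Compound 3 `CCCc1nc(-c2ccccc2)c(CNCCN2CCN(c3cccc(Cl)c3)CC2)o1` builds on compound 2 with the change (chloro in place of hydrogen on an aromatic carbon), placing the chlorine meta to a large group on that ring.

For the measured compounds named here, only one measured step bears on this change, and it stayed within the scatter, giving no sign that this ring position controls the numbers in this assay. The expected step of a 1.5-fold lower number from compound 2 to compound 3 (0.17 log units; within the scatter) is therefore small, with no clear direction beyond the scatter. Compound 3 is estimated at 7000 nM, within a range of 3000 nM to 20000 nM.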

Compound 3, half-maximal inhibitory concentration: 1450 nM
Estimate against measurement, compound 3: 4.8-fold (0.68 log units) above; the whole stated range lies above it.
By their numbers in this assay, from the lowest: compound 3; then compounds 1 and 2 (each within the scatter of the next).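

In this assay, chloro in place of hydrogen at this spot on the outer ring gives a 7.1-fold lower number from compound 2 to compound 3 (0.85 log units; beyond the scatter) and so shows that this ring position can affect the number, a sign that the earlier step from methoxy to hydrogen did not give. Measured against the methoxy-bearing compound, 3-chlorophenyl in place of 4-methoxyphenyl gives a 6.3-fold lower number from compound 1 to compound 3 (0.80 log units; beyond the scatter) and is a step of similar size, so the drop holds against both earlier compounds and not just one of them. Nothing available here explains why this chlorine lowers the number, and the reason remains unknown.

On these data alone, with a single chloro compound, it stays open whether the drop is tied to chlorine itself or whether another group at the same place, such as fluoro, bromo, methyl or trifluoromethyl, would give a step of similar size. As far as these compounds go, it is also open whether chlorine elsewhere on this ring, or two chlorines on it, would lower the number further, and whether the step would carry over to a changed core.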